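A few compounds are considered here, and "the series" means these few. Any claim that something is new, unique, unknown or untested is made for them only; others in the source may bear on it.

Compound 1 `CCO/N=C/Nc1cc(Cl)c(OC)c(Cl)c1` and compound 2 `CCCOc1c(Cl)cc(N/C=N/OCC)cc1Cl` are built on one core, while compound 3 `C#CCc1c(Cl)cc(N/C=N/OC)cc1Cl` and compound 4 `C#CCc1c(Cl)cc(N/C=N/OCCC)cc1Cl` are built on another. In a physicochemical assay for lipophilicity, measured as octanol-water partition (on this read-out higher numbers stand for higher lipophilicity and lower numbers for lower lipophilicity), compound 1 gives 3.7, compound 2 gives 4.6, and compound 3 gives 3.3. The difference between the two cores is not broken down here. From compound 1 to compound 2 the change is ethyl in place of hydrogen on a saturated chain carbon bound to an oxygen on an aromatic ring, and that step was a number 0.90 log units higher from compound 1 to compound 2 (beyond the scatter). From compound 3 to compound 4 the change is ethyl in place of hydrogen on a saturated chain carbon bound to an oxygen. The two places are not identical: in the first pair the oxygen sits on an aromatic ring, whereas in the second pair it does not, so the second change is the same kind of change, not the same one. Since the change adds two carbon atoms in both pairs, a step of roughly the size seen in compound 1 to compound 2, a number 0.90 log units higher from compound 1 to compound 2 (beyond the scatter), is expected for compound 4, namely a number 0.90 log units higher from compound 3 to compound 4 (beyond the scatter). Compound 4 is therefore estimated at 4.2, expected to fall between 3.9 and 4.5.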

Compound 4, partition coefficient: 4
For compound 4 the middle estimate is 0.20 log units above the measured one; measured number inside the range.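

In this assay, ethyl in place of hydrogen gave a number 0.70 log units higher from compound 3 to compound 4 (beyond the scatter), and the same kind of change on the other core gave a number 0.90 log units higher from compound 1 to compound 2 (beyond the scatter), so the direction of the step carried over from one core to the other in these two pairs. Among the compounds shown here, this does not establish a general rule: only two pairs are available, and the oxygen sits on an aromatic ring in one pair but not in the other, so the two steps are of the same kind without being the same change. Nothing given here accounts for the size of either step.

The compounds shown leave open whether a longer chain such as butyl, or a chain ending in an amine or a carboxylic acid, would move the number in the same direction on either core. They also leave open whether ethyl in place of hydrogen would give a similar step on a third core.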